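The source may report more compounds than this note shows. Statements on the series, on what has been measured and on what is new or still open speak of the compounds shown alone.

Measured so far in a functional assay on SK-OV-3 cells (Homo sapiens) for inhibition, read by CCK-8 assay, with a stated time of 70 h; on this read-out lower numbers stand for stronger inhibition and higher numbers for weaker inhibition:

- Compound 1 `COc1ccc(OCCOCCNC2CCCC2)cc1` gives 99100 nM
- Compound 2 `O=C(O)c1ccccc1COc1ccc(OCCOCCNC2CCCC2)cc1` gives > 100000 nM (a limit of the assay, not a number)
- Compound 3 `COC(=O)c1ccc(COc2ccc(OCCOCCNC3CCCC3)cc2)cc1` gives 6990 nM

Within the data shown here, compound 3 holds the lowest number here, and the only other true number belongs to compound 1. Compound 4 `COC(=O)c1ccccc1COc1ccc(OCCOCCNC2CCCC2)cc1` has the same atoms as compound 3, joined differently: 2-(methoxycarbonyl)phenyl in place of 4-(methoxycarbonyl)phenyl on a saturated chain carbon bound to an oxygen on an aromatic ring. Only the place of the methoxycarbonyl group on the ring changes.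

Among the measured compounds shown here, three measured steps bear on this. Adding 4-(methoxycarbonyl)phenyl to the core gave a 14-fold lower number from compound 1 to compound 3 (1.15 log units; beyond the scatter), a large gain. Adding 2-carboxyphenyl gave a number no lower from compound 1 to compound 2 (the limit leaves the size open), with no gain visible. For the measured compounds named here, the large at least 14-fold lower number from compound 2 to compound 3 (1.15 log units; beyond the scatter) changes both the group and its place, so it cannot separate the two, and no measured pair changes the place alone.

Compound 4 keeps the methoxycarbonyl group, so most of the gain seen in compound 3 is expected to remain, with a slight lean towards a higher number. The expected step is a 1.6-fold higher number from compound 3 to compound 4 (0.20 log units; within the scatter). For compound 4, the estimated value is 11000 nM, with an expected range from 3500 nM to 40000 nM.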

Compound 4, half-maximal inhibitory concentration: > 100000 nM
Compound 4: no number, only a limit; the forecaster's own chance of this, stated with the estimate: 5%; at least 9.0-fold (0.95 log units) between middle value and limit.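

With the same atoms and only the place on the ring changed, 2-(methoxycarbonyl)phenyl in place of 4-(methoxycarbonyl)phenyl gives an at least 14-fold higher number from compound 3 to compound 4 (1.15 log units; beyond the scatter) in this assay. Among these compounds, this separates what the earlier compounds could not: keeping the methoxycarbonyl group is not enough, and the gain of compound 3 over the core of compound 1 depends on where that group sits on the ring. Adding 2-(methoxycarbonyl)phenyl to the shared core gives a number no lower from compound 1 to compound 4 (the limit leaves the size open). The step from compound 2 to compound 4 cannot be read, because both of these values are a limit and not a number: the limit of > 100000 nM in this assay, at which 2 of the 4 values shown sit.

As far as these compounds go, it stays open whether the gain needs the methoxycarbonyl group itself, or whether an amide or a nitrile in its place in compound 3 would keep it. From the compounds shown here alone, how far compound 4 lies beyond its limit also stays open.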